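Fluoro replacing hydrogen on an aryl ring of a butenoic acid

This account rests on a few compounds, and the source may have more. Where it says the series, first, only, none or still open, it means among the compounds named here.

Compound 2, with the structure `O=C(O)/C=C/C(=O)c1ccccc1`, is tested in a functional assay on LS174T cells (Homo sapiens) for inhibition, read by MTT assay, with a stated time of 72 h (a lower number here means a stronger inhibitor, a higher number a weaker inhibitor), where compound 2 gives 45500 nM. Among the measured compounds shown here, that is the highest of the two numbers measured so far. For the measured compounds named here, its only neighbour is compound 1, with the structure `O=C(O)/C=C/C(=O)c1ccc(Br)cc1`, which in this assay gives 27100 nM; the step of a 1.7-fold higher number from compound 1 to compound 2 (0.23 log units; within the scatter) separates the two, and the data say this lies within the scatter.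

Compound 3, with the structure `O=C(O)/C=C/C(=O)c1ccc(F)cc1`, has not been measured yet. The change is fluoro in place of hydrogen on an aromatic carbon. Going by the values given here, the one measured step that bears on it is the one in which a halogen on the same aromatic carbon was swapped for hydrogen, a 1.7-fold higher number from compound 1 to compound 2 (0.23 log units; within the scatter), a move that stayed within the scatter. Putting a different halogen back at that place is therefore expected to shift the number little in this assay, if anything toward a slightly lower value, so that compound 3 is expected to show a 1.3-fold lower number from compound 2 to compound 3 (0.10 log units; within the scatter). The estimate for compound 3 in this assay is 36000 nM, with a range from 15000 nM to 85000 nM.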

Compound 3, half-maximal inhibitory concentration: 33800 nM
For compound 3 the middle estimate is 1.1-fold (0.03 log units) above the measured one, and the stated range covers the measured number.
By their numbers in this assay, from the lowest: compounds 1, 3 and 2 (each within the scatter of the next).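

In this assay, fluoro in place of hydrogen on an aromatic carbon gives a 1.3-fold lower number from compound 2 to compound 3 (0.13 log units; within the scatter) at the spot para to a group of 7 heavy atoms, and fluoro in place of bromo at that same spot gives a 1.2-fold higher number from compound 1 to compound 3 (0.10 log units; within the scatter) in the same test. With the earlier bromo and hydrogen pair, all three substituents at this one place have now been compared directly, and every step among them lies within the scatter, so the data give no ranking of hydrogen, fluoro and bromo here; a smaller halogen behaves no differently in these numbers from a larger one. Nothing is available that could explain these numbers or tie them to any property of the groups.

On these data alone, all three compounds carry only hydrogen or a halogen at this place, so it remains open whether an amine, a methoxy group or a longer chain there would move the number beyond the scatter. Also open, as far as these compounds go, is what a methyl ester or an amide would do in place of the carboxylic acid of the shared core.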